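The source may report more compounds than this note shows. Statements on the series, on what has been measured and on what is new or still open speak of the compounds shown alone.

Compound 3 `CCOC(=O)c1sc(NC(=O)Cn2cc(-c3ccc([N+](=O)[O-])cc3)nn2)nc1C` shows the highest number of the three measured compounds in a functional assay on BMDM cells (Mus musculus, strain C57BL/6) for inhibition, with a stated time of 2 days; a higher number here means a weaker inhibitor, a lower number a stronger inhibitor: compound 3 gives 1840 nM, while compound 1 `CCOC(=O)c1sc(NC(=O)Cn2cc(-c3ccc(Cl)cc3)nn2)nc1C` gives 180 nM and compound 2 `Cc1csc(NC(=O)Cn2cc(-c3ccc([N+](=O)[O-])cc3)nn2)n1` gives 190 nM. Compound 4 `CCOC(=O)c1sc(NC(=O)Cn2cc(-c3ccc(F)cc3)nn2)nc1C` differs from compound 3 by fluoro in place of nitro on an aromatic carbon. The step that bears on this change is a 10-fold higher number from compound 1 to compound 3 (1.01 log units; beyond the scatter), where a halogen was exchanged for nitro; here the reverse exchange is made, nitro for a halogen, though with fluoro rather than chloro. The step of a 9.7-fold higher number from compound 2 to compound 3 (0.99 log units; beyond the scatter) concerns a different part of the core and does not bear on it. A drop of roughly the earlier size is therefore expected, and the step expected for compound 4 is a 6.1-fold lower number from compound 3 to compound 4 (0.79 log units; beyond the scatter). Compound 4 is estimated at 300 nM, ranging from 100 nM to 900 nM.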

Compound 4, half-maximal inhibitory concentration: 660 nM
Compound 4: the middle estimate sits 2.2-fold (0.34 log units) below what was measured, within the range that was stated.
By their numbers in this assay, from the lowest: compounds 1 and 2 (each within the scatter of the next); then compound 4; then compound 3.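

Fluoro in place of nitro gives a 2.8-fold lower number from compound 3 to compound 4 (0.45 log units; beyond the scatter) in this assay and so improves on the nitro compound, but a second step of a 3.7-fold higher number from compound 1 to compound 4 (0.56 log units; beyond the scatter) keeps it short of the chloro compound. On this core, the two halogens are therefore not interchangeable at this position: chloro, fluoro and nitro give three separate levels, with every step beyond the scatter. Nothing available explains this order. Still open, going by these compounds, is how bromo, methoxy or an amine would fare at this position, and whether fluoro would hold its place on the core of compound 2, which lacks the ethoxycarbonyl.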